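Swapping the ester's aryl group on a selenium-bearing quinoline

The source may report more compounds than this note shows. Statements on the series, on what has been measured and on what is new or still open speak of the compounds shown alone.

Of the compounds shown here, three of a shared core have been tested in a functional assay on B16 cells (Mus musculus) for antiproliferative activity, with a stated time of 72 h; on this read-out higher numbers stand for weaker inhibition and lower numbers for stronger inhibition. Compound 1 `CSc1cnc2ccccc2c1SCC#CCO` gives 49.8 ug/mL, and compound 3 `C#CCSc1cnc2ccccc2c1SCC#CCCl` gives 52.8 ug/mL, so these two sit close together. Compound 2 `CSc1cnc2ccccc2c1[Se]CC#CCOC(=O)/C=C/c1ccccc1` gives 3.1 ug/mL, which is the lowest of the three numbers and therefore the strongest inhibition seen so far; its gaps to compound 1 and to compound 3 both lie well beyond the scatter of repeated measurements.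

Compound 4 `CSc1cnc2ccccc2c1[Se]CC#CCOC(=O)c1ccc(C(=O)O)cc1` has not yet been measured. It differs from compound 2 in one place: 4-carboxyphenyl in place of 2-phenylethenyl on a carbonyl carbon. In plain terms, the 2-phenylethenyl arm of the ester is traded for a 4-carboxyphenyl arm, bringing in one hydrogen-bond donor and one acceptor where there were none.

Among the measured compounds shown here, no measured pair in this set shows what such a change does, so the expectation rests on compound 2 alone, whose value of 3.1 ug/mL is the anchor. The step from compound 2 to compound 4 is expected to be modest and towards weaker inhibition, a 2.9-fold higher number from compound 2 to compound 4 (0.46 log units; beyond the scatter). Compound 4 is thus estimated to give 9 ug/mL in this assay, with a plausible range from 3 ug/mL to 30 ug/mL.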

Compound 4, concentration for 50% inhibition: 3.1 ug/mL
Estimate against measurement, compound 4: 2.9-fold (0.46 log units) above, within the range that was stated.
By their numbers in this assay, from the lowest: compounds 2 and 4 (each within the scatter of the next); then compounds 1 and 3 (each within the scatter of the next).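

In this assay, trading the 2-phenylethenyl arm of the ester for a 4-carboxyphenyl arm gives no change at the digits printed from compound 2 to compound 4 (within the scatter). On this carbonyl carbon, then, the strong inhibition seen with compound 2 survives a swap that brings in a hydrogen-bond donor and a hydrogen-bond acceptor where the old arm had none. Among the compounds shown here, this is the first pair here that differs in one place, so it gives the first direct reading of a change at this position, which compound 1 and compound 3 could not provide. No available evidence says why the two arms give matching numbers.

On these data alone, one swap leaves the wider limits of this position open, since both arms carry a six-membered aromatic ring of carbon only and a double bond outside aromatic rings, so it remains unknown whether the ring is needed at all. An ester ending in a plain methyl group, a longer saturated chain or an amine in place of the carboxylic acid would show how far the arm can move from these two before the number changes.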